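This account rests on a few compounds, and the source may have more. Where it says the series, first, only, none or still open, it means among the compounds named here.

Compound 1 `CCS(=O)(=O)Nc1cc(-c2ccc3ncnc(Nc4cccc(C(=O)OC)c4)c3c2)cnc1OC`: 1120 nM
Compound 2 `CCS(=O)(=O)Nc1cc(-c2ccc3ncnc(Nc4ccc(F)c(C(=O)OC)c4)c3c2)cnc1OC`: 2540 nM

Among the measured compounds shown here, in a functional assay on SNU-638 cells (Homo sapiens) for cytotoxicity, read by sulforhodamine B assay, with a stated time of 72 h (on this read-out higher numbers stand for weaker inhibition and lower numbers for stronger inhibition), compound 2 gives the highest of the two numbers; the only step measured among them is a 2.3-fold higher number from compound 1 to compound 2 (0.36 log units; beyond the scatter), a modest rise beyond the scatter. Compound 3 `CCS(=O)(=O)Nc1cc(-c2ccc3ncnc(Nc4ccc(Cl)c(C(=O)OC)c4)c3c2)cnc1OC` has not yet been measured in this assay. It differs from compound 2 by chloro in place of fluoro on an aromatic carbon. For the measured compounds named here, the one measured step that bears on this position is a 2.3-fold higher number from compound 1 to compound 2 (0.36 log units; beyond the scatter), in which a fluoro entered in place of hydrogen. Going by the values given here, no measured pair sets chloro against fluoro, so the expectation rests on that single step and on the fact that the substituent merely changes from one halogen to another. Compound 3 is expected to differ from its neighbour by a 1.3-fold higher number from compound 2 to compound 3 (0.10 log units; within the scatter), a step that may well fall within the scatter. In this assay compound 3 is therefore estimated at 3200 nM, within a range from 1200 nM to 8500 nM.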

Compound 3, half-maximal inhibitory concentration: 2200 nM
Compound 3: middle estimate off by 1.5-fold (0.16 log units), on the high side; low and high end bracket the measured number.
By their numbers in this assay, from the lowest: compounds 1, 3 and 2 (each within the scatter of the next, the first and the last beyond it).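

In this assay, with chloro in place of fluoro on the aromatic carbon ortho to the methoxycarbonyl group, the result is a 1.2-fold lower number from compound 2 to compound 3 (0.06 log units; within the scatter), so the two halogens cannot be told apart at this position. Set against hydrogen at the same place, chloro gives a 2.0-fold higher number from compound 1 to compound 3 (0.29 log units; within the scatter), so unlike fluoro in a 2.3-fold higher number from compound 1 to compound 2 (0.36 log units; beyond the scatter), it is not separated from the unsubstituted compound, although the fluoro and chloro compounds themselves read alike. Nothing available bears on why these halogens read as they do.

The compounds shown leave open whether a group other than a halogen at this position, such as a methoxy group, an amine or a nitrile, would read differently from hydrogen. They also leave open whether a carboxylic acid or an amide in place of the methoxycarbonyl group would alter the reading.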